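This account rests on a few compounds, and the source may have more. Where it says the series, first, only, none or still open, it means among the compounds named here.

Measured in a functional assay on DU-145 cells (Homo sapiens) for cytotoxicity, read by MTT assay, with a stated time of 48 h; on this read-out lower numbers stand for stronger inhibition and higher numbers for weaker inhibition:
Compound 1 `C=C1CCC[C@]2(C)CCC(C=O)=CC[C@@]12C`: 152000 nM
Compound 2 `CC1(C)CCCC2=CC=C(C=O)CC[C@]21C`: 191000 nM

Going by the values given here, only two numbers are available so far, and they lie within the usual scatter of each other. Compound 1 therefore cannot be ranked against compound 2, and the two simply share one level of effect.

The next compound to be tested is compound 3 `C#CC1=CC[C@@]2(C)C(=C)CCC[C@]2(C)CC1`. It keeps the core of compound 1 and carries ethynyl in place of formyl on a double-bonded ring carbon. Among the compounds with values here, compound 2 also carries formyl, and no measured pair shows what replacing that group does. Within the data shown here, the only guide is therefore the level already seen, with compound 1 at 152000 nM.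

On that basis, no shift beyond the scatter is expected in this assay, and no direction can be favoured. The estimated 1.0-fold lower number from compound 1 to compound 3 (0.01 log units; within the scatter) stays small. For compound 3 the expected value is 150000 nM, with an estimated range from 50000 nM to 400000 nM.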

Compound 3, half-maximal inhibitory concentration: 387000 nM
Compound 3: middle estimate off by 2.6-fold (0.41 log units), on the low side; measured number inside the range.
By their numbers in this assay, from the lowest: compounds 1 and 2 (each within the scatter of the next); then compound 3.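

In this assay, going by these compounds alone, replacing formyl with ethynyl on a double-bonded ring carbon of the seven-membered ring gives a 2.5-fold higher number from compound 1 to compound 3 (0.41 log units; beyond the scatter) and is the first single change seen to move the number beyond the usual scatter. The step is modest, but it shows that this position is not indifferent to what sits on it, and that this swap goes towards weaker inhibition rather than stronger. The swap removes the hydrogen-bond acceptor counted for formyl and brings in a triple bond, yet this one pair cannot separate those differences, and nothing measured here explains the rise.

Going by these compounds, it remains open whether another group at this ring carbon, such as a nitrile, a carboxylic acid or an amine, would bring the number below that of compound 1 or raise it further. On these data alone, it is also open whether the same exchange of formyl for ethynyl on compound 2, which carries formyl on a different core, would give a step of similar size and direction.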